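Replacing a hydroxyphenyl hydrazone group with a thiophene group

The source may report more compounds than this note shows. Statements on the series, on what has been measured and on what is new or still open speak of the compounds shown alone.

Measured in a functional assay on MCF7 cells (Homo sapiens) for antiproliferative activity, read by MTT assay, with a stated time of 72 h (a higher number here means a weaker inhibitor, a lower number a stronger inhibitor), so far:
- Compound 1 `CCCSc1nc(N/N=C(\C)c2ccc(O)cc2)c2nnn(Cc3ccccc3)c2n1` gives 21600 nM
- Compound 2 `CCCSc1nc(N/N=C(\C)c2ccc(OC)cc2)c2nnn(Cc3ccccc3)c2n1` gives > 64000 nM as a limit of the assay
- Compound 3 `C/C(=N\Nc1nc(SCc2ccccc2)nc2c1nnn2Cc1ccccc1)c1ccccc1O` gives 950 nM

In this assay compound 3 gives 950 nM and compound 1 gives 21600 nM as the higher of the two exact numbers. Compound 2 gives > 64000 nM which is a limit of the assay, not a number.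

Compound 4 `CCCSc1nc(N/N=C/c2cccs2)c2nnn(Cc3ccccc3)c2n1` has not yet been measured. It differs from compound 1 as follows: a group of 7 heavy atoms (5 carbon, 1 nitrogen, 1 sulfur; one five-membered aromatic ring with 1 hetero atom) in place of a group of 10 heavy atoms (8 carbon, 1 nitrogen, 1 oxygen; one six-membered aromatic ring of carbon only), on a nitrogen on an aromatic ring (on a nitrogen on an aromatic ring). Among the compounds with values here, one measured step bears on this: an at least 2.9-fold higher number from compound 1 to compound 2 (0.47 log units; beyond the scatter) with methyl in place of hydrogen on an oxygen on an aromatic ring, inside the group that leaves. That single step points towards a higher number, but the swap here is much larger, so in this assay only a small rise, within the scatter, is expected. The expected size is a 1.2-fold higher number from compound 1 to compound 4 (0.06 log units; within the scatter) by this estimate. For compound 4 the estimated value is 25000 nM with an expected range from 5000 nM to 64000 nM in this estimate.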

Compound 4, half-maximal inhibitory concentration: > 64000 nM
Compound 4: a limit, no number; the forecaster's own chance of this, stated with the estimate: 25%; middle value at least 2.5-fold (0.40 log units) away from the limit.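

In this assay, putting the thiophene group in place of the hydroxyphenyl hydrazone group on the nitrogen on an aromatic ring gives an at least 2.9-fold higher number from compound 1 to compound 4 (0.47 log units; beyond the scatter), so this position does not accept every replacement of that group. From the compounds shown here alone, the value of compound 4 is a limit of the assay, and the true size of the step stays unknown because a limit is not a number: the limit of > 64000 nM in this assay, at which 2 of the 4 values shown sit. Among the compounds shown, the two without a hydroxyl group, compound 2 and compound 4, both end at this limit, while compound 1 and compound 3, which carry one, give numbers.

The swap changes the ring, the hydroxyl group and the methyl on the hydrazone together, and the compounds shown do not separate these changes. Going by these compounds, it also remains open how an amine or a carboxylic acid in place of the hydroxyl group would behave in this assay.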